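A few compounds are considered here, and "the series" means these few. Any claim that something is new, unique, unknown or untested is made for them only; others in the source may bear on it.

Measured in a functional assay on CAKI-1 cells (Homo sapiens) for inhibition, read by sulforhodamine B assay, with a stated time of 48 h; a lower number here means a stronger inhibitor of growth, a higher number a weaker inhibitor of growth:
- compound 1 `COc1ccc(-c2cc(/C=C/C(=O)c3ccc(N)cc3)[nH]n2)cc1` gives 1320 nM
- compound 2 `COc1cc(-c2cc(/C=C/C(=O)c3ccc(Cl)c(Cl)c3)[nH]n2)cc(OC)c1OC` gives 16900 nM
- compound 3 `COc1ccc(C(=O)/C=C/c2cc(-c3cc(OC)c(OC)c(OC)c3)n[nH]2)cc1` gives 2340 nM

Compound 2 stands with the highest number of the three; its nearest neighbour is compound 3, and from compound 2 to compound 3 the number falls by a 7.2-fold lower number from compound 2 to compound 3 (0.86 log units; beyond the scatter), and compound 1 lies further still, with the gap to compound 2 beyond the scatter. Compounds 1 and 3 differ in more than one place, and their two values lie within the scatter of each other.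

Compound 4 `COc1cc(-c2cc(/C=C/C(=O)c3ccc(F)c(F)c3)[nH]n2)cc(OC)c1OC` is to be measured in this assay. Its change from compound 2 is 3,4-difluorophenyl in place of 3,4-dichlorophenyl on a carbonyl carbon. Within the data shown here, no measured step covers a swap of one halogen pair for another on this phenyl; the only step that touches the same place, from compound 2 to compound 3, replaced the whole 3,4-dichlorophenyl by 4-methoxyphenyl. That step gives no direction for a halogen exchange, so the expected step in this assay is small, likely within the scatter, with a slight lean toward a lower number. The expected step is a 1.4-fold lower number from compound 2 to compound 4 (0.15 log units; within the scatter). Compound 4 is estimated at 12000 nM, with a range from 4000 nM to 40000 nM.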

Compound 4, concentration for 50% growth inhibition: 2980 nM
Estimate against measurement, compound 4: 4.0-fold (0.60 log units) above; measured number outside the range, below it.
By their numbers in this assay, from the lowest: compounds 1, 3 and 4 (each within the scatter of the next, the first and the last beyond it); then compound 2.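

At the phenyl on the carbonyl carbon, this assay separates the two halogen pairs: a 5.7-fold lower number from compound 2 to compound 4 (0.75 log units; beyond the scatter), with the rest of the molecule unchanged. The earlier step at this place removed both chlorines and added a methoxy group at once, so it could not show that a change of halogen alone moves the number beyond the scatter. Among these compounds, the 3,4-difluorophenyl and 4-methoxyphenyl groups give values within the scatter of each other, a 1.3-fold higher number from compound 3 to compound 4 (0.11 log units; within the scatter), leaving 3,4-dichlorophenyl as the one group of the three set apart in this short set.

Nothing on hand accounts for the gap between the two halogen pairs. From the compounds shown here alone, how an unsubstituted phenyl, a single fluorine, a trifluoromethyl group or a nitrile on this ring would compare remains open.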